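Swapping an aromatic pyrrole for pyrrolidine: effect on cytotoxicity

The source may hold more compounds than are shown below. What is called first, only, known or untested is meant among the compounds shown, and "the series" means these compounds.

Measured compounds:
compound 1, `COC(=O)c1ccc(NCc2cncn2Cc2ccc(C)cc2)cc1-c1ccccc1` — 50000 nM in a toxicity assay on NIH3T3 cells (Mus musculus) for cytotoxicity, read by resazurin assay; a higher number here means that more compound is needed for the effect, a lower number that less compound is needed
compound 2, `c1ccc(-c2ccc(Cn3cncc3CNc3ccc(-c4ccc[nH]4)c(-c4ccccc4)c3)cc2)cc1` — > 10000 nM
compound 3, `Cc1cccc(-c2cccc(NCc3cncn3Cc3ccccc3)c2)c1` — > 1000 nM

Of the compounds shown here, three have been tested for how much of each is needed to harm mouse fibroblast cells. For compound 1 the result is a number, 50000 nM. For compound 2 the result is only a limit of the assay, > 10000 nM, and not a number. For compound 3 the result is likewise a limit, > 1000 nM. Since two of the three results are limits (the limit of > 1000 nM in this assay, at which 1 of the 3 values shown sits, and (the limit of > 10000 nM in this assay, at which 1 of the 3 values shown sits)), compound 2 cannot be placed in any order against the others; what can be said is that none of the three harms the cells at low concentration.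

Compound 4, `c1ccc(-c2ccc(Cn3cncc3CNc3ccc(N4CCCC4)c(-c4ccccc4)c3)cc2)cc1`, has not yet been measured. It differs from compound 2 in one place: pyrrolidin-1-yl in place of 1H-pyrrol-2-yl on an aromatic carbon. The pyrrol-2-yl group that leaves and the pyrrolidin-1-yl group that enters are of the same size, and the rest of the shared core is unchanged.

Among the measured compounds shown here, no measured pair in this set differs in a single place, so there is no directly comparable step to lean on. Given that compound 2 sits at a limit, > 10000 nM, compound 4 is expected to stay weakly cytotoxic as well. The step that the limit leaves unreadable from compound 2 to compound 4 is expected to be none beyond the scatter. Compound 4 is estimated at 20000 nM, with a range from 5000 nM to 60000 nM, and a fair chance that only a limit is reported again.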

Compound 4, half-maximal effective concentration: > 1000 nM
Compound 4 was reported as a limit; the forecaster's own chance of this, stated with the estimate: 60%; the middle value lies beyond the limit too.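

Compound 2 and compound 4 are both reported only as limits of the assay and not as numbers, so no step can be read from putting pyrrolidin-1-yl in place of 1H-pyrrol-2-yl. Still open, going by these compounds, is how much of either compound is needed for an effect in this assay, and whether this swap changes that amount at all.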